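The compounds below may be only part of what the source reports. "The series", "measured", "known", "first", "only" and "open" are said of these compounds alone.

Measured compounds:
Compound 1, `CCCn1c(Br)nc2c(N)nc(NCc3ccccc3)nc21`, in a functional assay on CHO cells for antagonist activity at adenosine receptor A2b (Homo sapiens); a higher number here means a weaker inhibitor, a lower number a stronger inhibitor: 1740 nM
Compound 2, `CCCn1cnc2c(NCc3ccccc3)ncnc21`, in this assay: > 30000 nM, which is a limit of the assay and not a number

Compound 2 stands at the weak end of what has been recorded. Its reading in this assay is > 30000 nM, a limit and not a number, as noted in the limit of > 30000 nM in this assay, at which 1 of the 2 values shown sits. Among the measured compounds shown here, compound 1 has a measured value in this assay of 1740 nM, but it differs from compound 2 in more than one place, so no single step joins the two. Compound 3, `CCCn1c(-c2ccco2)nc2c(NCc3ccccc3)ncnc21`, has not yet been measured. It differs from compound 2 by furan-2-yl in place of hydrogen on an aromatic carbon. For the measured compounds named here, no measured step covers this change, so the size is uncertain; a modest move toward stronger inhibition is expected, an at least 5.0-fold lower number from compound 2 to compound 3 (0.69 log units; beyond the scatter), beyond the usual scatter. For compound 3 the expected value in this assay is 6000 nM, within a range from 1000 nM to 30000 nM.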

Compound 3, inhibition constant: 1760 nM
The estimate for compound 3 lay 3.4-fold (0.53 log units) above the measured number; the measured number falls inside the stated range.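

In this assay, furan-2-yl in place of hydrogen on an aromatic carbon, between two ring nitrogen atoms and next to the ring atom that bears a propyl group, gives an at least 17-fold lower number from compound 2 to compound 3 (1.23 log units; beyond the scatter). Compound 2 stands at > 30000 nM, which is a limit of the assay and not a number, so this step gives only a minimum size: the limit of > 30000 nM in this assay, at which 1 of the 3 values shown sits. This is the only single-place change shown at this position, and it shows that replacing hydrogen with furan-2-yl here takes the reading from a limit to a measured number.

From the compounds shown here alone, whether a phenyl ring, a methyl group or an amine on this carbon would give a similar reading remains open. Also open, going by these compounds, is whether furan-2-yl would have a similar effect on the core of compound 1.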